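Swapping a benzoxazole for a triazole on the thioether

The compounds below may be only part of what the source reports. "The series", "measured", "known", "first", "only" and "open" are said of these compounds alone.

Of the compounds shown here, two sharing one core have been tested in a functional assay on HT-29 cells (Homo sapiens) for cytotoxicity, read by MTT assay, with a stated time of 24 h, tested at 16 ug/mL; on this read-out lower numbers stand for a weaker effect and higher numbers for a stronger effect at the one concentration tested. Compound 1 `Cn1c(-c2ccc(NC(=O)CSc3nc4cc(Cl)ccc4o3)cc2)nc(-c2ccccc2)c1-c1ccccc1` gives 42.5%. Compound 2 `Cc1ccc2oc(SCC(=O)Nc3ccc(-c4nc(-c5ccccc5)c(-c5ccccc5)n4C)cc3)nc2c1` gives 37.7%. The step between them, a number 4.8 percentage points lower from compound 1 to compound 2 (within the scatter), is small, so on the numbers shown compound 2 cannot be told apart from compound 1; the two read as the same.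

Compound 3 `Cn1cnnc1SCC(=O)Nc1ccc(-c2nc(-c3ccccc3)c(-c3ccccc3)n2C)cc1` has not yet been measured. It differs from compound 2 by 4-methyl-4H-1,2,4-triazol-3-yl in place of 5-methyl-1,3-benzoxazol-2-yl on a sulfur. For the measured compounds named here, this is a larger change than the one between compound 1 and compound 2, and it sits at another place in the molecule. Going by the values given here, the single measured step, a number 4.8 percentage points lower from compound 1 to compound 2 (within the scatter), therefore says little about it, beyond showing that a small change at an aromatic carbon left the read-out within the scatter.

With nothing to anchor the direction, the expectation for compound 3 is a moderate step downward, a number 5.7 percentage points lower from compound 2 to compound 3 (within the scatter), with wide uncertainty. Compound 3 is estimated at 32%, with a range from 12% to 52%.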

Compound 3, a percentage reported as activity, at one concentration (the size of the read-out at that concentration, not a potency): 59.1%
Beside the measured number, compound 3's estimate is 27.1 percentage points below it, and the stated range ends below it.
By their numbers in this assay, from the lowest: compounds 2 and 1 (each within the scatter of the next); then compound 3.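

For the compounds shown here, the group on the sulfur is the first place where a change moves the read-out in this assay beyond the scatter. The step is a number 21.4 percentage points higher from compound 2 to compound 3 (beyond the scatter) with the 5-methyl-1,3-benzoxazol-2-yl group replaced, and a number 16.6 percentage points higher from compound 1 to compound 3 (beyond the scatter) with the 5-chloro-1,3-benzoxazol-2-yl group replaced, so 4-methyl-4H-1,2,4-triazol-3-yl, a single five-membered ring with 6 heavy atoms, stands higher than either of the two larger groups, whichever of methyl or chloro they carry. No measured evidence is available to explain this rise.

This one change alters ring count, size and hetero atoms all at once, so the compounds shown cannot tell which of these differences goes with the higher number, and a single concentration gives the size of the effect rather than a potency. From the compounds shown here alone, it remains open whether a plain phenyl ring on the same sulfur, or an ethyl group in place of the methyl on the triazole, would keep the read-out at the level of compound 3.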